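Swapping an imidazole for dimethylamino on the chain

The source may hold more compounds than are shown below. What is called first, only, known or untested is meant among the compounds shown, and "the series" means these compounds.

Measured so far:
Compound 1 `COC(=O)N(C)CC#CCN1CCCC1`: > 10 mg/kg
Compound 2 `COC(=O)N(C)CC#CCn1ccnc1`: > 100 mg/kg

In a functional assay on the whole organism for antagonist activity, with Mus musculus as the target (on this read-out higher numbers stand for an effect only at larger amounts of compound and lower numbers for an effect already at smaller amounts), compound 2 reports only a limit, > 100 mg/kg, and not a number. Compound 1 also reports only a limit, > 10 mg/kg. Neither compound therefore has a firm position on this scale.

Compound 3 `COC(=O)N(C)CC#CCN(C)C` has not yet been measured. It carries dimethylamino in place of 1H-imidazol-1-yl on a saturated chain carbon bound to a triple-bonded carbon.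

Going by the values given here, the one measured step that bears on this change is a step that the two limits leave unreadable from compound 1 to compound 2. It also involves removing or adding 1H-imidazol-1-yl, but its size cannot be read, so it offers only a weak hint about direction. A move towards smaller doses in this assay is expected, though another limit remains quite possible.

The expected change is an at least 3.3-fold lower number from compound 2 to compound 3 (0.52 log units; beyond the scatter).

For compound 3 the estimate is 30 mg/kg, with an expected range from 5 mg/kg to 200 mg/kg.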

Compound 3, dose for half-maximal effect: > 30 mg/kg
Compound 3: no number, only a limit (the forecaster's own chance of this, stated with the estimate: 65%); the middle value lies on the limit itself.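

Going by these compounds alone, compound 1, compound 2 and compound 3 each give only a limit in this assay, not a number, and no step among them can be read. The compounds shown leave open whether pyrrolidin-1-yl, 1H-imidazol-1-yl and dimethylamino differ at all in the dose they need for half-maximal effect.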